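Methoxy for chloro at the para position: compound 4

A few compounds are considered here, and "the series" means these few. Any claim that something is new, unique, unknown or untested is made for them only; others in the source may bear on it.

Measured so far:
compound 1 `Cc1nnc(SCC(=O)N/N=c2/scc(-c3ccccc3)n2-c2ccccc2)s1` — 72.5%
compound 2 `Cc1nnc(SCC(=O)N/N=c2/scc(-c3ccc(F)cc3)n2-c2ccccc2)s1` — 73.7%
compound 3 `Cc1nnc(SCC(=O)N/N=c2/scc(-c3ccc(Cl)cc3)n2-c2ccccc2)s1` — 76.6%

In a functional assay on C6 cells (Rattus norvegicus) for cytotoxicity, read by MTT assay, with a stated time of 24 h, tested at 12 ug/mL (a higher number here means a weaker effect of the compound at the concentration tested, a lower number a stronger effect), compound 3 gives 76.6%; its steps to the others, a number 4.1 percentage points higher from compound 1 to compound 3 (within the scatter) and a number 2.9 percentage points higher from compound 2 to compound 3 (within the scatter), both fall within the scatter, so the three numbers read as one level. Compound 4 `COc1ccc(-c2cs/c(=N/NC(=O)CSc3nnc(C)s3)n2-c2ccccc2)cc1` is not yet measured. The change: methoxy in place of chloro on an aromatic carbon. Within the data shown here, no measured step swaps chloro for methoxy; the nearest cases, a number 1.2 percentage points higher from compound 1 to compound 2 (within the scatter) and a number 2.9 percentage points higher from compound 2 to compound 3 (within the scatter), exchange halogen for hydrogen or for halogen and stay within the scatter. The step of a number 1.6 percentage points lower from compound 3 to compound 4 (within the scatter) is therefore expected to be none beyond the scatter. Compound 4 is estimated at 75%, with a range from 62% to 88%.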

Compound 4, a percentage reported as activity, at one concentration (the size of the read-out at that concentration, not a potency): 53.6%
Compound 4: middle estimate off by 21.4 percentage points, on the high side; measured number outside the range, below it.
By their numbers in this assay, from the lowest: compound 4; then compounds 1, 2 and 3 (each within the scatter of the next).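

In this assay the steps of a number 23 percentage points lower from compound 3 to compound 4 (beyond the scatter) and a number 20.1 percentage points lower from compound 2 to compound 4 (beyond the scatter) and a number 18.9 percentage points lower from compound 1 to compound 4 (beyond the scatter) set the 4-methoxyphenyl compound apart from the other three, with a stronger effect at the concentration tested. The place on an aromatic carbon para to a large group therefore responds to the group it carries: hydrogen, fluoro and chloro read as one level, while methoxy does not. No measurement at hand bears on why methoxy behaves differently.

As far as these compounds go, whether the shift is particular to methoxy or also appears with ethoxy, hydroxy or an amine remains open. So does whether it holds at other concentrations.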